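Amide aryl swap on the cyclohexylmethyl series

The source may hold more compounds than are shown below. What is called first, only, known or untested is meant among the compounds shown, and "the series" means these compounds.

Compound 3 `Cc1cccc(C(=O)Nn2c(CC3CCCCC3)nc3c(-c4ccc(Cl)cc4)n[nH]c3c2=O)c1` gives 1070 nM in a functional assay on DU-145 cells (Homo sapiens) for inhibition, read by MTT assay, with a stated time of 2 days (on this read-out higher numbers stand for weaker inhibition of growth and lower numbers for stronger inhibition of growth), the lowest of the three numbers. Within the data shown here, compound 2 `CCCCCc1nc2c(-c3ccc(Cl)cc3)n[nH]c2c(=O)n1NC(=O)c1cccc(C)c1` gives 12900 nM and compound 1 `COc1cccc(-c2nc3c(-c4ccc(Cl)cc4)n[nH]c3c(=O)n2NC(=O)c2ccccc2)c1` gives 17900 nM; the only single-place step, a 12-fold lower number from compound 2 to compound 3 (1.08 log units; beyond the scatter), sits on the chain carbon, not on the amide aryl. Compound 4 `CC(C)(C)c1ccc(C(=O)Nn2c(CC3CCCCC3)nc3c(-c4ccc(Cl)cc4)n[nH]c3c2=O)cc1` carries 4-(tert-butyl)phenyl in place of 3-methylphenyl on a carbonyl carbon. Among the measured compounds shown here, no measured step touches this part of the molecule, so nothing here shows how the amide aryl moves the number. The expectation for compound 4 is therefore a step of about a 1.2-fold higher number from compound 3 to compound 4 (0.08 log units; within the scatter), within the scatter. Compound 4 is estimated at 1300 nM, with a range from 400 nM to 4500 nM.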

Compound 4, concentration for 50% growth inhibition: > 100000 nM
Compound 4 ended at the assay's limit; the forecaster's own chance of this, stated with the estimate: 3%; middle value at least 76-fold (1.88 log units) away from the limit.
By their numbers in this assay, from the lowest: compound 3; then compounds 2 and 1 (each within the scatter of the next). At a limit, above all of these: compound 4.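

The amide aryl is now shown to matter on the cyclohexylmethyl series: 4-(tert-butyl)phenyl in place of 3-methylphenyl on a carbonyl carbon gives an at least 93-fold higher number from compound 3 to compound 4 (1.97 log units; beyond the scatter). The change at this position is at least as large as the chain step, a 12-fold lower number from compound 2 to compound 3 (1.08 log units; beyond the scatter), and runs the opposite way. Compound 4 stands at a limit of this assay, so the full size of its step stays unknown: the limit of > 100000 nM in this assay, at which 1 of the 4 values shown sits.

Compound 3 and compound 4 differ in both the substituent and its ring position, and these two changes cannot be separated here. As far as these compounds go, how a 4-methylphenyl or a 3-aminophenyl would read on this carbonyl carbon remains open.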